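The source may hold more compounds than are shown below. What is called first, only, known or untested is meant among the compounds shown, and "the series" means these compounds.

Compound 1 `O=C(NCCCCn1ccnc1)c1ccc(Cl)nc1` gives 8000 nM in an assay on isolated protein for inhibition of Thromboxane-A synthase (Rattus norvegicus); on this read-out higher numbers stand for weaker inhibition and lower numbers for stronger inhibition.
Compound 2 `CC(CCNC(=O)c1cc2cc(Cl)ccc2[nH]1)n1ccnc1` gives 50 nM in this assay.

Of these two measured compounds, compound 1 stands with the highest number in this assay; the nearest value, that of compound 2, is lower by a gap that lies well beyond the usual scatter of repeated measurements. Compound 1 and compound 2 differ in more than one place, so that gap tells nothing about any single change.

Compound 3 `O=C(NCCCCCn1ccnc1)c1ccc(Cl)nc1` has not yet been measured. It differs from compound 1 in one place only: (1H-imidazol-1-yl)methyl in place of 1H-imidazol-1-yl on a saturated chain carbon, four bonds along the chain from an amide-type nitrogen. Going by the values given here, no pair of measured compounds shows a change of this kind, so there is no measured step to lean on; the only guide is where compound 1 itself stands in this assay.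

Lengthening the chain by one member is a small change, and for compound 3 the expected step of a 2.0-fold lower number from compound 1 to compound 3 (0.30 log units; within the scatter) is a slight lowering of the number, close to the edge of the scatter. For compound 3 the estimate in this assay is 4000 nM, expected to fall between 800 nM and 20000 nM.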

Compound 3, half-maximal inhibitory concentration: 3000 nM
Estimate against measurement, compound 3: 1.3-fold (0.12 log units) above; measured number inside the range.
By their numbers in this assay, from the lowest: compound 2; then compound 3; then compound 1.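

In this assay, going by these compounds alone, (1H-imidazol-1-yl)methyl in place of 1H-imidazol-1-yl on a saturated chain carbon gives a 2.7-fold lower number from compound 1 to compound 3 (0.43 log units; beyond the scatter), and this is the first single change that can be read on its own. It shows that the read-out responds to a change at this place, four bonds along the chain from an amide-type nitrogen, even though the imidazole ring and the core of compound 1 stay the same. The step is modest, however, and nothing in the data shown accounts for it.

Going by these compounds, it remains open whether a longer chain ending in the same 1H-imidazol-1-yl would lower the number further or raise it again, as a single step cannot show whether the trend continues. On these data alone, it is also open whether a simple amine or a carboxylic acid at the end of the chain could take the place of the imidazole ring, and whether the same change would have a similar effect on a different core.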